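This account rests on a few compounds, and the source may have more. Where it says the series, first, only, none or still open, it means among the compounds named here.

Measured so far in a physicochemical assay for lipophilicity, using the shake flask method, measured as octanol-water partition, at pH 7.4 (a lower number here means a more polar compound, a higher number a more lipophilic compound), for two compounds:
- compound 1 `CCC(CC)CNc1c(C(N)=O)cnc2ccc(C#N)cc12` gives 3.5
- compound 2 `CCC(CC)CNc1c(C(N)=O)cnc2ccc(-c3ccc(CO)nc3)cc12` gives 3.7

Compound 2 at 3.7 has only compound 1 to stand against, and the two lie within the scatter of each other. Compound 3 `CCC(CC)CNc1c(C(N)=O)cnc2ccc(-c3ccc(COC)nc3)cc12` awaits measurement. Its change is methyl in place of hydrogen on an oxygen on a saturated carbon with methyl in place of hydrogen on an oxygen on a saturated carbon, which turns hydroxymethyl into methoxymethyl. Going by the values given here, the one measured step is a number 0.20 log units higher from compound 1 to compound 2 (within the scatter) with 6-(hydroxymethyl)pyridin-3-yl in place of cyano on an aromatic carbon. Among the compounds with values here, that is a different change, so it gives no direct size for this one, and no measured pair compares hydroxy with methoxy. Within the data shown here, it shows only that the numbers in this assay stayed within the scatter across that replacement. On the structural change alone, a modest move to a higher number is expected in this assay and may only just clear the scatter. The expected size is a number 0.40 log units higher from compound 2 to compound 3 (beyond the scatter) and remains an estimate only. For compound 3 the estimated value is 4.1 with an expected range from 3.7 to 4.5 pending measurement.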

Compound 3, distribution coefficient: > 4.3
Compound 3 was reported as a limit (the forecaster's own chance of this, stated with the estimate: 5%); middle value at least 0.20 log units away from the limit.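

Compound 3 is reported in this assay only as a limit and not as a number: the limit of > 4.3 in this assay, at which 1 of the 3 values shown sits.

Methyl in place of hydrogen on an oxygen on a saturated carbon, which turns hydroxymethyl into methoxymethyl, gives a number at least 0.60 log units higher from compound 2 to compound 3 (beyond the scatter), and this is the first measured comparison of hydroxy with methoxy in the series. Replacing cyano on an aromatic carbon now also gives a step beyond the scatter, a number at least 0.80 log units higher from compound 1 to compound 3 (beyond the scatter), whereas the hydroxymethyl counterpart gave a number 0.20 log units higher from compound 1 to compound 2 (within the scatter), so at this place in this assay the outcome of replacing cyano depends on whether that oxygen carries hydrogen or methyl, at least for these compounds.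

As far as these compounds go, the full size of both new steps stays open, since each rests on a limit and fixes only a lower bound. Also open, from the compounds shown here alone, is how this assay responds to other groups at the same place, such as an ethyl on that oxygen, an amine in place of the hydroxy, or a carboxylic acid in place of the hydroxymethyl.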